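This account rests on a few compounds, and the source may have more. Where it says the series, first, only, none or still open, it means among the compounds named here.

Measured compounds in a functional assay on HCT-15 cells (Homo sapiens) for cytotoxicity, read by CCK-8 assay and cell counting, with a stated time of 2 days; a lower number here means a stronger inhibitor, a higher number a weaker inhibitor:
Compound 1 `Oc1ccc(-c2cc(-c3ccccc3)nc(-c3ccccc3Cl)c2)cc1` gives 4990 nM.
Compound 2 `Oc1ccc(-c2cc(-c3ccc(Cl)cc3)nc(-c3cccnc3)c2)cc1` gives 20700 nM.
Compound 3 `Oc1ccc(-c2cc(-c3ccc(Cl)cc3)nc(-c3cccs3)c2)cc1` gives 6470 nM.

Within the data shown here, compound 2 stands at the highest of these three numbers: compound 3 sits nearest to it, and the one step recorded between measured compounds runs a 3.2-fold lower number from compound 2 to compound 3 (0.51 log units; beyond the scatter), a replacement of pyridin-3-yl by thiophen-2-yl. Compound 1 lies furthest from compound 2, below it, and the two values show that difference without a recorded step.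

Compound 4 `Oc1cccc(-c2cc(-c3ccc(Cl)cc3)nc(-c3cccnc3)c2)c1` differs from compound 2 by 3-hydroxyphenyl in place of 4-hydroxyphenyl on an aromatic carbon. Among the measured compounds shown here, no measured step bears on this change: the only recorded step, from compound 2 to compound 3, alters a different group on the shared core and says nothing about the hydroxyphenyl group. Without any pair in this assay that probes the hydroxyphenyl group, the estimate for compound 4 is expected to stay close to compound 2, with no step beyond the scatter in either direction; the expected step is a 1.0-fold lower number from compound 2 to compound 4 (0.01 log units; within the scatter). Compound 4 is therefore expected to give about 20000 nM, within a range from 7000 nM to 60000 nM.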

Compound 4, half-maximal inhibitory concentration: 16800 nM
For compound 4 the middle estimate is 1.2-fold (0.08 log units) above the measured one; measured number inside the range.
By their numbers in this assay, from the lowest: compounds 1 and 3 (each within the scatter of the next); then compounds 4 and 2 (each within the scatter of the next).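

Among these compounds, compound 4 gives the first pair that probes the hydroxyphenyl group, the substituent on the shared core that stands opposite the ring nitrogen. In this assay the exchange of 4-hydroxyphenyl for 3-hydroxyphenyl gives a 1.2-fold lower number from compound 2 to compound 4 (0.09 log units; within the scatter), so with the 4-chlorophenyl and pyridin-3-yl groups held fixed, the two arrangements cannot be told apart, whereas the change at the other position gives a 3.2-fold lower number from compound 2 to compound 3 (0.51 log units; beyond the scatter) and lies beyond the scatter. Nothing available here accounts for this result.

Going by these compounds, this comparison rests on a single pair carrying pyridin-3-yl, so whether 3-hydroxyphenyl and 4-hydroxyphenyl also match alongside thiophen-2-yl, or on the core of compound 1, remains open. Also open, on these data alone, is how this assay responds when a methoxy group or an amine takes the place of the hydroxyl group on this ring.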